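This account rests on a few compounds, and the source may have more. Where it says the series, first, only, none or still open, it means among the compounds named here.

Compound 1 `CCC(=O)Nc1c(C(O)(C(F)(F)F)C(F)(F)F)ccc2ccccc12` is one of two members of a small set tested in a functional assay (Sus scrofa) with sulfonylurea receptors; K-ATP channels (Homo sapiens) as the target; on this read-out lower numbers stand for an effect already at smaller amounts and higher numbers for an effect only at larger amounts of compound; in this assay compound 1 gives 8.91 nM, the lowest of the two numbers. For the measured compounds named here, its neighbour compound 2 `CC(C)=CC(=O)Nc1c(C(O)(C(F)(F)F)C(F)(F)F)ccc2ccccc12` gives 550 nM in this assay, and the step of a 62-fold higher number from compound 1 to compound 2 (1.79 log units; beyond the scatter) is the only measured change at the carbonyl carbon. Compound 3 `C/C=C/C(=O)Nc1c(C(O)(C(F)(F)F)C(F)(F)F)ccc2ccccc12` has not yet been measured; it differs from compound 1 in that (prop-1-en-1-yl in place of ethyl on a carbonyl carbon). Going by the values given here, the one step that bears on this, a 62-fold higher number from compound 1 to compound 2 (1.79 log units; beyond the scatter), also introduced a double bond on the carbonyl carbon and raised the number strongly. Compound 3 carries the same double bond in the prop-1-en-1-yl group, so a rise beyond the scatter is expected in this assay, though a smaller one than the measured step. For compound 3 the expected value in this assay is 80 nM, within 20 nM to 320 nM, a step of a 9.0-fold higher number from compound 1 to compound 3 (0.95 log units; beyond the scatter).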

Compound 3, half-maximal effective concentration: 49 nM
Beside the measured number, compound 3's estimate is 1.6-fold (0.21 log units) above it; the measured number falls inside the stated range.
By their numbers in this assay, from the lowest: compound 1; then compound 3; then compound 2.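

In this assay, replacing ethyl with prop-1-en-1-yl on the carbonyl carbon gives a 5.5-fold higher number from compound 1 to compound 3 (0.74 log units; beyond the scatter), so a second change at this position also moves the number up, and ethyl remains the group with the lowest number among the three. The further comparison, an 11-fold lower number from compound 2 to compound 3 (1.05 log units; beyond the scatter), shows that the double bond alone does not set the size of the rise: the two groups that carry one differ clearly from each other, and 2-methylprop-1-en-1-yl gives the larger step away from compound 1. No measurement offered here gives a reason for these differences.

The compounds shown leave open whether the rise follows the double bond or the longer group, a question that a saturated propyl group at this position would address. They also leave open how a cyclopropyl group or a longer butyl chain would read.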